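Benzoyl for Acetyl on Two Thiourea Cores

This account rests on a few compounds, and the source may have more. Where it says the series, first, only, none or still open, it means among the compounds named here.

This set concerns three measured thioureas and one that remains to be measured, all tested in an assay for inhibition of epoxide hydrolase 1 (Homo sapiens), read by fluorescence, using microsomes; on this read-out higher numbers stand for weaker inhibition and lower numbers for stronger inhibition. Compound 1, `O=C(NC(=S)Nc1ccc(Oc2ccccc2)cc1)c1ccccc1`, gives 2100 nM in this assay. Compound 2, `CC(=O)NC(=S)Nc1ccc(Oc2ccccc2)cc1`, gives 3700 nM. Compound 3, `CC(=O)NC(=S)Nc1ccc(Br)c2ccccc12`, gives 2420 nM; compound 3 and compound 1 lie within the scatter of each other, as do compound 3 and compound 2.

Compound 4, `O=C(NC(=S)Nc1ccc(Br)c2ccccc12)c1ccccc1`, is not yet measured. It differs from compound 3 in one place, (phenyl in place of methyl on a carbonyl carbon). The very same change has been made once before among these compounds, from compound 2 to compound 1, (phenyl in place of methyl on a carbonyl carbon), where it brought a 1.8-fold lower number from compound 2 to compound 1 (0.25 log units; within the scatter). The two cores on which the change sits are not alike, and the difference between the core of compound 3 and the core of compound 2 is not broken down here. Since the place of the change reads the same in both pairs, it counts as the same change.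

On that single precedent, the step from compound 3 to compound 4 in this assay is expected to be about a 1.7-fold lower number from compound 3 to compound 4 (0.24 log units; within the scatter), resting on the step seen in this assay from compound 2 to compound 1 and on the value of compound 3, 2420 nM. Among the measured compounds shown here, compound 4 is therefore estimated at 1400 nM, with a likely range from 600 nM to 3500 nM; with only one earlier example of this change, the range is kept wide.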

Compound 4, half-maximal inhibitory concentration: 1880 nM
Estimate against measurement, compound 4: 1.3-fold (0.13 log units) below; the range from low to high includes it.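

In this assay, putting phenyl in place of methyl on a carbonyl carbon gives a 1.3-fold lower number from compound 3 to compound 4 (0.11 log units; within the scatter), and the comparison with the earlier case on the other core reads: the same change on two cores in this assay, a 1.8-fold lower number (0.25 log units; within the scatter) from compound 2 to compound 1 and a 1.3-fold lower number (0.11 log units; within the scatter) from compound 3 to compound 4, 1.4-fold (0.14 log units) apart, within the scatter of two such steps

Taken together, the two pairs show that this change carries from one core to the other without any visible difference in outcome: on both cores, the step from methyl to phenyl stays small enough to be lost in the ordinary spread of repeated measurements. They do not show that phenyl gives stronger inhibition than methyl on either core, since neither step can be told apart from noise, and a match between two steps of this size says little about how the change would behave on a core outside this set, or about a case in which the step is large.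

The compounds shown leave open what other groups on this carbonyl carbon would do, such as ethyl, a longer chain, or a phenyl ring carrying an amine or a carboxylic acid. They also leave open whether any such group would shift the number beyond the scatter, and whether it would do so equally on both cores.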